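Methoxy entering on the phenyl of compound 1

This account rests on a few compounds, and the source may have more. Where it says the series, first, only, none or still open, it means among the compounds named here.

Compound 1 `COc1cc2c(cc1OC)C(CC(=O)Nc1ccccc1)CC2` gives 42.8% in a functional assay on the whole organism (strain Swiss Albino) for inhibition, with Mus musculus as the target, in the writhing test, with a stated time of 1 h, at a dose of 100 mg/kg by the oral route (a lower number here means less inhibition, a higher number more inhibition at the dose given (going by the name of the read-out)), and stands second highest of the three numbers; compound 3 `COc1cc2c(cc1OC)C(CC(=O)Nc1ccc(Br)cc1)CC2` gives 37.5%, within the scatter of compound 1, while compound 2 `COc1cc2c(cc1OC)C(CC(=O)Nc1ccc(Cl)cc1)CC2` gives 73.6%, beyond the scatter and higher. The change to compound 4 `COc1ccccc1NC(=O)CC1CCc2cc(OC)c(OC)cc21` is methoxy in place of hydrogen on an aromatic carbon. Among the compounds with values here, no measured step places a methoxy anywhere, and the halogen steps on the phenyl point in no single direction: a number 30.8 percentage points higher from compound 1 to compound 2 (beyond the scatter), whereas a number 5.3 percentage points lower from compound 1 to compound 3 (within the scatter), and a number 36.1 percentage points lower from compound 2 to compound 3 (beyond the scatter). Substitution on that ring has therefore shifted the read-out either way or not at all, so for compound 4 in this assay no step beyond the scatter is expected in either direction. The estimate for compound 4 is 45%, range 25% to 65%, an expected a number 2.2 percentage points higher from compound 1 to compound 4 (within the scatter).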

Compound 4, a percentage reported as inhibition, in the whole organism at one dose (the size of the read-out at that dose, not a potency): 24.5%
For compound 4 the middle estimate is 20.5 percentage points above the measured one; the measured number lies below the stated range.
By their numbers in this assay, from the lowest: compound 4; then compounds 3 and 1 (each within the scatter of the next); then compound 2.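

Methoxy, ortho to a large group, is the first substituent on the phenyl of compound 1 to lower the number beyond the scatter in this assay (a number 18.3 percentage points lower from compound 1 to compound 4 (beyond the scatter)). Compound 4 also falls beyond the scatter against both halogen compounds (a number 13 percentage points lower from compound 3 to compound 4 (beyond the scatter); a number 49.1 percentage points lower from compound 2 to compound 4 (beyond the scatter)), so it stands lowest of the four. No measurement shown accounts for this drop.

Going by these compounds, whether the drop belongs to methoxy itself or to its place on the ring stays open. An amine or a carboxylic acid at this position also remains untested among the compounds shown.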